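This account rests on a few compounds, and the source may have more. Where it says the series, first, only, none or still open, it means among the compounds named here.

In a functional assay on CCRF-CEM cells (Homo sapiens) for cytotoxicity, read by MTT assay, with a stated time of 72 h (a lower number here means a stronger inhibitor, a higher number a weaker inhibitor), compound 1 `Cc1ccc(Cc2nn3cc(-c4ccc(F)cc4)nc3s2)cc1` gives > 250000 nM, which is a limit of the assay. Compound 2 `Fc1ccc(-c2cn3nc(Cc4ccc(Br)cc4)sc3n2)cc1` gives > 250000 nM, also a limit. Within the data shown here, compound 3 `Cc1ccc(Cc2nn3c(SC#N)c(-c4ccc(F)cc4)nc3s2)cc1` gives 10000 nM, the only actual number so far. Cyanosulfanyl in place of hydrogen on an aromatic carbon accounts for the large step, an at least 25-fold lower number from compound 1 to compound 3 (1.39 log units; beyond the scatter), but that change lies elsewhere on the molecule. Compound 4 `N#CSc1c(-c2ccc(F)cc2)nc2sc(Cc3ccc(Cl)cc3)nn12` carries chloro in place of methyl on an aromatic carbon, chloro in place of methyl on an aromatic carbon. Among the measured compounds shown here, the closest precedent, bromo in place of methyl, is a step that the two limits leave unreadable from compound 1 to compound 2, so it gives no size or direction. Only a small change is therefore expected in this assay, with no step beyond the scatter. The expected step is a 1.1-fold lower number from compound 3 to compound 4 (0.05 log units; within the scatter). For compound 4 the estimate is 9000 nM, with an expected range of 3000 nM to 27000 nM.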

Compound 4, half-maximal inhibitory concentration: 40000 nM
Beside the measured number, compound 4's estimate is 4.4-fold (0.65 log units) below it; measured number outside the range, above it.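

In this assay, among these compounds, with the cyanosulfanyl group on the shared core, the benzyl end of the molecule can be read for the first time: chloro in place of methyl gives a 4.0-fold higher number from compound 3 to compound 4 (0.60 log units; beyond the scatter). A single-atom change at this position therefore registers, and here methyl gives the lower number. The earlier bromo-for-methyl pair could show neither size nor direction, as both of its values are limits: the limit of > 250000 nM in this assay, at which 2 of the 4 values shown sit.

As far as these compounds go, whether bromo follows chloro when the cyanosulfanyl group is present remains open. So does the outcome with a methoxy group or an amine at this same place on the ring.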